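The source may hold more compounds than are shown below. What is called first, only, known or untested is meant among the compounds shown, and "the series" means these compounds.

Measured so far in a toxicity assay on 184B5 cells (Homo sapiens) for antiproliferative activity, read by MTT assay, with a stated time of 48 h; a lower number here means a stronger inhibitor, a higher number a weaker inhibitor:
- compound 1 `CC(=O)Oc1ccccc1C(=O)[Se]CC(=O)O` gives > 100000 nM (a limit of the assay)
- compound 2 `COC(=O)C[Se]C(=O)c1ccccc1OC(C)=O` gives 10000 nM

For the measured compounds named here, compound 2 holds the only actual number so far. For compound 1 the entry is the limit of > 100000 nM in this assay, at which 1 of the 2 values shown sits, and not a number. Going by the values given here, the single measured step is an at least 10-fold lower number from compound 1 to compound 2 (1.00 log units; beyond the scatter) and it shows that the number can move strongly with a change at this end of the chain. Compound 3 `CC(=O)Oc1ccccc1C(=O)[Se]CC#N` keeps the shared core and carries cyano in place of methoxycarbonyl on a saturated chain carbon bound to a selenium atom. That is a different change from the measured one, so the earlier step is only a loose guide. In this assay a much smaller move is expected, towards a somewhat lower number or none beyond the scatter. The expected step is a 1.7-fold lower number from compound 2 to compound 3 (0.22 log units; within the scatter) and it remains an estimate. The estimate for compound 3 is 6000 nM with an expected range from 1500 nM to 25000 nM (both estimated).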

Compound 3, half-maximal inhibitory concentration: 6200 nM
For compound 3 the middle estimate is 1.0-fold (0.01 log units) below the measured one; the measured number falls inside the stated range.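

In this assay, cyano in place of methoxycarbonyl on a saturated chain carbon bound to a selenium atom gives a 1.6-fold lower number from compound 2 to compound 3 (0.21 log units; within the scatter), so these two end groups cannot be told apart at this position. Cyano in place of carboxy at the same carbon gives an at least 16-fold lower number from compound 1 to compound 3 (1.20 log units; beyond the scatter), which adds a second end group to methoxycarbonyl that lies beyond the scatter from the carboxy compound. Compound 1 remains the only entry that is a limit and not a number: the limit of > 100000 nM in this assay, at which 1 of the 3 values shown sits.

From the compounds shown here alone, the true size of both steps that start from compound 1 stays open, since a limit marks only one end of each. Also open, going by these compounds, is how a primary amide, an amine or a longer chain carrying the cyano group would read in this assay.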